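Methoxy for chloro in the dithiol anilide series

The compounds below may be only part of what the source reports. "The series", "measured", "known", "first", "only" and "open" are said of these compounds alone.

compound 1 `O=C(CCCCC(S)CCS)Nc1ccc(Cl)cc1`: 18.2%
compound 2 `Cc1cccc(NC(=O)CCCCC(S)CCS)c1`: 7.23%

In a functional assay on KB cells (Homo sapiens) for inhibition, read by MTT assay, with a stated time of 24 h, tested at 10 ug/mL (a higher number here means more inhibition of growth at the concentration tested, a lower number less inhibition of growth), compound 1 stands highest of the two measured compounds at 18.2%, and compound 2 lies lower at 7.23%, a gap beyond the usual scatter.

The next compound is compound 3 `COc1ccc(NC(=O)CCCCC(S)CCS)cc1`, which keeps the core of compound 1 and carries methoxy in place of chloro on an aromatic carbon, para to a large group. No measured pair differs in one place only, so the size of this change in this assay is not shown directly. A small downward step, within the scatter, is expected, with the estimate resting on the two values above. The expected change is a number 6.2 percentage points lower from compound 1 to compound 3 (within the scatter). Compound 3 is estimated at 12%, with an expected range of 3% to 24%.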

Compound 3, percent growth inhibition at one concentration: 8.93%
Estimate against measurement, compound 3: 3.1 percentage points above, within the range that was stated.
By their numbers in this assay, from the lowest: compounds 2, 3 and 1 (each within the scatter of the next, the first and the last beyond it).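

In this assay, among the compounds shown here, compounds 1 and 3 form the first pair that differs in one place only, and the step is a number 9.3 percentage points lower from compound 1 to compound 3 (within the scatter). Methoxy and chloro on this aromatic carbon, para to a large group, are therefore not separated by this read-out, even though the swap replaces 1 heavy atom with 2 and adds 1 hydrogen-bond acceptor. No measurement available here speaks to what underlies this step.

Open, on these data alone, is whether an amine, a carboxylic acid or a nitrile at this same position would give a step beyond the scatter. Also open, as far as these compounds go, is whether methoxy for chloro behaves the same way with a longer chain in place of the dithiol chain on the shared core.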